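Trading a nitro-bearing ring for a methyl-bearing one

The compounds below may be only part of what the source reports. "The series", "measured", "known", "first", "only" and "open" are said of these compounds alone.

Three compounds have been measured in a functional assay on SK-OV-3 cells (Homo sapiens) for inhibition, read by CCK-8 assay, with a stated time of 70 h; on this read-out higher numbers stand for weaker inhibition and lower numbers for stronger inhibition:

Compound 1, `COc1cc(OCCOCCNC2CCCC2)ccc1OCc1ccccc1`, gives 44600 nM
Compound 2, `O=[N+]([O-])c1cccc(COc2ccc(OCCOCCNC3CCCC3)cc2)c1`, gives 15400 nM
Compound 3, `c1ccc(COc2ccc(OCCOCCNC3CCOC3)cc2)cc1`, gives 48000 nM

Compound 2 stands lowest of the three, meaning the strongest inhibition seen so far. Its nearest neighbour is compound 1 and its furthest is compound 3; both gaps lie beyond the usual scatter of this assay, so the difference is real rather than noise.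

Compound 4, `Cc1ccc(COc2ccc(OCCOCCNC3CCCC3)cc2)cc1`, has not yet been measured. It differs from compound 2 in one place: 4-methylphenyl in place of 3-nitrophenyl on a saturated chain carbon bound to an oxygen on an aromatic ring.

Compounds 1 and 3, which carry no nitro group on that ring, both give clearly higher numbers than compound 2, although each also differs elsewhere in its structure. Taken as a rough guide, the step from compound 2 to compound 4 is expected to move upward, beyond the scatter: a 2.3-fold higher number from compound 2 to compound 4 (0.36 log units; beyond the scatter). In this assay compound 4 is therefore expected to give about 35000 nM, with a range from 12000 nM to 100000 nM.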

Compound 4, half-maximal inhibitory concentration: 17200 nM
The estimate for compound 4 lay 2.0-fold (0.31 log units) above the measured number, and the stated range covers the measured number.
By their numbers in this assay, from the lowest: compounds 2 and 4 (each within the scatter of the next); then compounds 1 and 3 (each within the scatter of the next).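

In this assay, replacing 3-nitrophenyl with 4-methylphenyl on a saturated chain carbon bound to an oxygen on an aromatic ring gives a 1.1-fold higher number from compound 2 to compound 4 (0.05 log units; within the scatter), which is within the scatter, so the two compounds cannot be told apart. This direct comparison shows that, in this pair, the nitro group is not required for the inhibition seen with compound 2, something compounds 1 and 3 could not show because each also differs elsewhere. Nothing available explains why these two groups give matching numbers.

This single step changes both the group on the ring and its printed location, so the two changes cannot be separated. As far as these compounds go, it also remains open whether a carboxylic acid or an amine on this ring would move the number beyond the scatter.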